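The compounds below may be only part of what the source reports. "The series", "measured", "known", "first", "only" and "open" are said of these compounds alone.

In a functional assay on SK-MEL-28 cells (Homo sapiens) for inhibition (a lower number here means a stronger inhibitor, a higher number a weaker inhibitor), compound 1 (`COCCOc1cc(/C=C/c2ccc3ccccc3c2)ccc1OC`) gives 2990 nM and compound 2 (`COCCOc1cc(/C=C\c2ccc3ccccc3c2)ccc1OC`) gives 2990 nM, so compound 2 stands level with compound 1 at the digits shown. Among the measured compounds shown here, the one measured step (no change at the digits printed from compound 1 to compound 2 (within the scatter)) is a change of configuration only (the fact that compounds 1 and 2 differ only in the configuration as drawn) and stays within the scatter. Compound 3 (`Cc1ccc(/C=C/c2ccc3ccccc3c2)cc1`) is reported only as a limit of the assay (> 5000 nM).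

Compound 4 (`COc1ccc(/C=C\c2ccc3ccccc3c2)cc1N`) differs from compound 2 by amino in place of 2-methoxyethoxy on an aromatic carbon, ortho to a methoxy group (amino in place of 2-methoxyethoxy on an aromatic carbon). For the measured compounds named here, no measured step covers an exchange of this kind, and the configuration step sets no size for it. The estimate therefore rests on compound 2 (2990 nM) as its only anchor and is held loosely. The expected move in this assay is toward stronger inhibition, with an estimated size of a 6.0-fold lower number from compound 2 to compound 4 (0.78 log units; beyond the scatter) and a wide margin either way. For compound 4 the estimated value is 500 nM (expected range 40 nM to 4000 nM).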

Compound 4, half-maximal inhibitory concentration: > 20000 nM
Compound 4 gave a limit, no number; the forecaster's own chance of this, stated with the estimate: 12%; middle value at least 40-fold (1.60 log units) away from the limit.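

In this assay, this position is not indifferent to its substituent: amino in place of 2-methoxyethoxy on an aromatic carbon, ortho to a methoxy group, gives an at least 6.6-fold higher number from compound 2 to compound 4 (0.82 log units; beyond the scatter). The configuration step, no change at the digits printed from compound 1 to compound 2 (within the scatter), gave no sign of this, whereas the exchange at this position moves the read-out beyond the scatter toward weaker inhibition. Compound 4 is reported only as a limit of the assay, so the step has a lower bound and no exact size: the limit of > 20000 nM in this assay, at which 1 of the 4 values shown sits.

From the compounds shown here alone, whether the weakening comes from removing the 2-methoxyethoxy chain or from introducing the amino group stays open; this pair changes both at once. An ethoxy chain, a hydroxyl or an acetamide at the same position would help to separate these two contributions.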